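Chloro for nitro on the phenol ring of compound 3

This account rests on a few compounds, and the source may have more. Where it says the series, first, only, none or still open, it means among the compounds named here.

The series shares an aryl enone bearing two chloro groups and an ether-linked acetamide, and differs in the amine part. Compound 1 `C=C(CC)C(=O)c1ccc(OCC(=O)Nc2ccc3c(C)cc(=O)oc3c2)c(Cl)c1Cl` carries a coumarin-type amine, compound 2 `C=C(CC)C(=O)c1ccc(OCC(=O)Nc2nc(/C(=N\OC)C(=O)O)cs2)c(Cl)c1Cl` a thiazole with an oxime acid, and compound 3 `C=C(CC)C(=O)c1ccc(OCC(=O)Nc2ccc(O)c([N+](=O)[O-])c2)c(Cl)c1Cl` a phenol with a nitro group. In a functional assay on CLL cells (Homo sapiens) for cytotoxicity, read by MTT assay, with a stated time of 48 h (on this read-out higher numbers stand for an effect only at larger amounts of compound and lower numbers for an effect already at smaller amounts), compound 1 gives 2800 nM. For compound 2 the assay reports only a limit, > 25000 nM, and no number. In this assay compound 3 gives 7400 nM, the highest of the two numbers obtained; compound 1 sits well below it, and that gap is beyond the scatter.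

The next compound, compound 4 `C=C(CC)C(=O)c1ccc(OCC(=O)Nc2ccc(O)c(Cl)c2)c(Cl)c1Cl`, changes one group on that phenol ring: chloro in place of nitro on an aromatic carbon. Among the measured compounds shown here, no pair of measured compounds shows this change, so its effect is unknown from the data. For the measured compounds named here, with only one measurement in either direction to go by, the step is expected to stay modest, and to fall within or barely beyond the scatter, in either direction. Compound 4 is therefore estimated at 6000 nM, with a range from 2500 nM to 15000 nM, which corresponds to an expected step of a 1.2-fold lower number from compound 3 to compound 4 (0.09 log units; within the scatter).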

Compound 4, half-maximal effective concentration: 5500 nM
Estimate against measurement, compound 4: 1.1-fold (0.04 log units) above; low and high end bracket the measured number.
By their numbers in this assay, from the lowest: compounds 1, 4 and 3 (each within the scatter of the next, the first and the last beyond it). At a limit, above all of these: compound 2.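

In this assay, among the compounds shown here, the exchange of nitro for chloro, on the aromatic carbon ortho to a hydroxy group, is read as a 1.3-fold lower number from compound 3 to compound 4 (0.13 log units; within the scatter) and gives the first measured step at this position. It shows that a group of three heavy atoms with two hydrogen-bond acceptors can give way here to a single chlorine with none, while the read-out stays within the scatter, so for this pair the nitro group is not required for the cytotoxic effect on these cells. No measurement shown bears on why the two groups give such similar numbers.

The compounds shown leave open whether this tolerance extends to other groups at the same place, such as an amine, a methoxy group or a carboxylic acid, or holds only for nitro and chloro. They also leave open what the hydroxy group contributes, since every phenol shown keeps it, and a compound with hydrogen or a methyl ether in its place would be needed to read that step.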